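What a Chloro May Do to Compound 3

The source may hold more compounds than are shown below. What is called first, only, known or untested is meant among the compounds shown, and "the series" means these compounds.

Within the data shown here, in an ADME assay on a cell-free system (plasma, Homo sapiens) for protein binding (on this read-out higher numbers stand for a larger free fraction and lower numbers for a smaller free fraction), compound 3 (`CC(C)COc1ccc(-c2cn(C)c3cc(C(=O)NS(C)(=O)=O)c(F)cc23)cn1`) gives 0.008, the only actual number among the three compounds measured so far. Compound 1 (`CC(C)COc1ncc(-c2cn(C)c3cc(C(=O)NS(C)(=O)=O)ccc23)cc1Cl`) returns only a limit of the assay (< 0.001). Compound 2 (`CC(C)COc1ncc(-c2cn(C)c3cc(C(=O)NS(=O)(=O)C4CC4)c(F)cc23)cc1Cl`) also returns only a limit (< 0.001).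

Compound 4 (`CC(C)COc1ncc(-c2cn(C)c3cc(C(=O)NS(C)(=O)=O)c(F)cc23)cc1Cl`) differs from compound 3 in one place: chloro in place of hydrogen on an aromatic carbon. Compound 1 and compound 2 carry this chloro as well, but each also differs from compound 4 elsewhere, so neither gives a clean comparison. Among the measured compounds shown here, still, the only compound without the chloro is compound 3 (0.008), and it is the only one that gave a number. A clear fall in this assay beyond the usual scatter is therefore expected (a 6.7-fold lower number from compound 3 to compound 4 (0.82 log units; beyond the scatter)). The assay may well report only a limit for the new compound. The estimate for compound 4 is 0.0012 (expected range 0.0005 to 0.003).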

Compound 4, unbound fraction: 0.001
Compound 4: the middle estimate sits 1.2-fold (0.08 log units) above what was measured; the measured number falls inside the stated range.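

The chloro on the aromatic carbon ortho to an isobutoxy group now has a clean size in this assay: there is an 8.0-fold lower number from compound 3 to compound 4 (0.90 log units; beyond the scatter), which brings compound 4 to 0.001, a number at the very edge of what this read-out reports: the limit of < 0.001 in this assay, at which 2 of the 4 values shown sit.

Compound 1 and compound 2 also carry this chloro but gave only limits. The steps from each of them to compound 4 cannot be read: there is a number no lower from compound 2 to compound 4 (the limit leaves the size open) and there is a number no lower from compound 1 to compound 4 (the limit leaves the size open). The fluoro and the cyclopropyl differences therefore still have no size.

As far as these compounds go, this size for the chloro comes from a single pair on a single background, so whether it holds alongside other groups on the shared core stays open. Also open, from the compounds shown here alone, is what a bromo or a nitrile on the same carbon, or an amine or a longer chain in place of the isobutoxy group, would do in this assay.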